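The source may hold more compounds than are shown below. What is called first, only, known or untested is meant among the compounds shown, and "the series" means these compounds.

Three related compounds have been read so far in an ADME assay on cells (Hepatocyte, Homo sapiens) for metabolic stability, with a stated time of 30 min (on this read-out higher numbers stand for a more stable compound and lower numbers for a less stable compound), to date. Compound 1 (`O=c1cc(N2CCN(CC3CCCCC3)CC2)sc2c(NO)cc(C(F)(F)F)cc12`) gives 19.1% there, and compound 2 (`Cc1ccc(C(=O)OC2CCC(CN3CCN(c4cc(=O)c5cc(C(F)(F)F)cc([N+](=O)[O-])c5s4)CC3)CC2)cc1`) gives 9.7% on the same read-out, so these two lie within the scatter of each other. Compound 3 (`Nc1cc(C(F)(F)F)cc2c(=O)cc(N3CCN(CC4CCC(O)CC4)CC3)sc12`) gives 72.9% and stands beyond the scatter from compound 2, which therefore sits at the low end of the set together with compound 1.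

Compound 4 (`O=C(OC1CCC(CN2CCN(c3cc(=O)c4cc(C(F)(F)F)cc([N+](=O)[O-])c4s3)CC2)CC1)c1ccc(F)cc1`) has not yet been measured. It departs from compound 2 in one place only: fluoro in place of methyl on an aromatic carbon is the whole difference, fluoro in place of methyl on an aromatic carbon, para to a large group, so that 4-methylphenyl becomes 4-fluorophenyl. Going by the values given here, no pair of measured compounds shows what this swap does in this assay for this set.

All the rest of compound 2 is kept, so the expectation starts from compound 2 at 9.7% and allows only a small move. The estimated step of a number 3.3 percentage points higher from compound 2 to compound 4 (within the scatter) is a slight rise that is expected to stay within the scatter. For compound 4 the estimated value is 13% with an expected range from 5% to 28% on this read-out.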

Compound 4, percent of the compound remaining: 3%
Compound 4: middle estimate off by 10 percentage points, on the high side; measured number outside the range, below it.
By their numbers in this assay, from the lowest: compounds 4, 2 and 1 (each within the scatter of the next, the first and the last beyond it); then compound 3.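

In this assay, going by these compounds alone, the step of a number 6.7 percentage points lower from compound 2 to compound 4 (within the scatter) gives the first reading of fluoro in place of methyl on an aromatic carbon, para to a large group, in this set. At this position, the change from 4-methylphenyl to 4-fluorophenyl therefore leaves the read-out within the scatter, and compound 4, at 3%, is not told apart from its methyl counterpart, compound 2. Nothing in the available data gives a reason for this reading.

This single pair leaves open whether the same exchange would also stay within the scatter on another member of the series, and whether another group on this aromatic carbon, such as an amine, a carboxylic acid or a longer chain, would give a step beyond it. It also leaves open how much the ((4-methylphenyl)carbonyl)oxy unit as a whole contributes to the reading in this assay, as no pair shown changes that unit beyond this one substituent.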